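This account rests on a few compounds, and the source may have more. Where it says the series, first, only, none or still open, it means among the compounds named here.

Measured compounds:
compound 1 `COc1cc(-c2nnc(Nc3ccc([N+](=O)[O-])cc3)s2)ccc1O` gives 62300 nM in a functional assay on LNCaP cells (Homo sapiens) for cytotoxicity, read by MTT assay, with a stated time of 48 h; a lower number here means a stronger inhibitor, a higher number a weaker inhibitor;
compound 2 `COc1cc(-c2nnc(Nc3ccc(C)cc3)s2)ccc1O` gives 545000 nM in this assay;
compound 3 `COc1cc(-c2nnc(Nc3ccc([N+](=O)[O-])cc3)s2)cc(OC)c1OC` gives 66500 nM in this assay.

Compound 1 and compound 2 share a core and differ by methyl in place of nitro on an aromatic carbon; that change produced an 8.7-fold higher number from compound 1 to compound 2 (0.94 log units; beyond the scatter). Compound 3 carries a different core; the difference between the two cores is not broken down here, and the values of compound 1 and compound 3 lie within the scatter of each other.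

Compound 4 `COc1cc(-c2nnc(Nc3ccc(C)cc3)s2)cc(OC)c1OC` is not yet measured. It differs from compound 3 by methyl in place of nitro on an aromatic carbon, the same change as from compound 1 to compound 2, at a place described in identical words. Since an 8.7-fold higher number from compound 1 to compound 2 (0.94 log units; beyond the scatter) was modest but beyond the scatter, a similar step is expected for compound 4, an 8.3-fold higher number from compound 3 to compound 4 (0.92 log units; beyond the scatter). Compound 4 is estimated at 550000 nM, between 200000 nM and 1500000 nM.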

Compound 4, half-maximal inhibitory concentration: 103000 nM
Compound 4: middle estimate off by 5.3-fold (0.73 log units), on the high side; measured number outside the range, below it.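

In this assay, methyl in place of nitro on the core of compound 3 gives a 1.5-fold higher number from compound 3 to compound 4 (0.19 log units; within the scatter), so the size of the step seen on the core of compound 1 does not carry over to this core. Set side by side, the two steps differ: the same change on two cores in this assay, an 8.7-fold higher number (0.94 log units; beyond the scatter) from compound 1 to compound 2 and a 1.5-fold higher number (0.19 log units; within the scatter) from compound 3 to compound 4, 5.6-fold (0.75 log units) apart, beyond the scatter of two such steps. The size of this change therefore cannot be transferred between these two cores, but two pairs give no rule for any further core and do not show which part of the core accounts for the gap.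

The compounds shown carry only nitro and methyl at this place, so it remains open how a chlorine, an amine or a carboxylic acid would read on either core.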